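Methoxyphenyl for methoxyindolyl: a single untested step

A few compounds are considered here, and "the series" means these few. Any claim that something is new, unique, unknown or untested is made for them only; others in the source may bear on it.

Compound 1 `COc1ccc2c(OCc3nnc4sc(-c5cccn5C)nn34)ccnc2c1` has no result in a functional assay on EBC-1 cells (Homo sapiens) for antiproliferative activity, with a stated time of 72 h; on this read-out higher numbers stand for weaker inhibition and lower numbers for stronger inhibition: for compound 1 the entry reads "not determined" (no result reported). For the measured compounds named here, compound 2 `COc1ccc2[nH]c(-c3nn4c(COc5ccnc6cc(OC)ccc56)nnc4s3)cc2c1` is the only compound with a number: in this assay compound 2 gives 85.6 nM. Compound 3 `COc1cccc(-c2nn3c(COc4ccnc5cc(OC)ccc45)nnc3s2)c1` differs from compound 2 by 3-methoxyphenyl in place of 5-methoxy-1H-indol-2-yl on an aromatic carbon. Going by the values given here, no measured pair isolates this change. Since the 5-methoxy-1H-indol-2-yl group leaving compound 2, which stands at 85.6 nM, counts one hydrogen-bond donor and a second ring that the entering 3-methoxyphenyl lacks, a modest loss is expected, a 2.9-fold higher number from compound 2 to compound 3 (0.47 log units; beyond the scatter), likely beyond the scatter. Compound 3 is expected at 250 nM, within 80 nM to 900 nM.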

Compound 3, half-maximal inhibitory concentration: 472 nM
Estimate against measurement, compound 3: 1.9-fold (0.28 log units) below; low and high end bracket the measured number.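

For the compounds shown here, at this aromatic carbon next to the ring sulfur, 3-methoxyphenyl in place of 5-methoxy-1H-indol-2-yl gives a 5.5-fold higher number from compound 2 to compound 3 (0.74 log units; beyond the scatter) in this assay and is the first readable step here, showing that the position is sensitive to this exchange. The change removes the hydrogen-bond donor and the five-membered aromatic ring together, so this step cannot separate the two. No measurement available bears on the origin of the step.

Open, on these data alone, is whether a simple phenyl without methoxy would stand nearer compound 2 or compound 3. Also open, as far as these compounds go, is how an amine or a carboxylic acid on the phenyl ring of compound 3 would read.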